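Working notes: lengthening the side chain of compound 1

A few compounds are considered here, and "the series" means these few. Any claim that something is new, unique, unknown or untested is made for them only; others in the source may bear on it.

Measured in a functional assay on MCF7 cells (Homo sapiens) for cytotoxicity, read by MTT assay, with a stated time of 72 h; a lower number here means a stronger inhibitor, a higher number a weaker inhibitor:
- compound 1 `O=C(NCc1ccc(F)cc1)c1nc(NCCO)c2cccnc2c1O`: "not determined" (no result reported)
- compound 2 `CN(C)c1ccc(CNC(=O)c2nc(Br)c3cccnc3c2N[C@H]2CC[C@H](N)CC2)cc1`: 5000 nM

Compound 1 has no place on the scale: in this assay compound 1 stands as "not determined" (no result reported), so it gives no number to start from. For the measured compounds named here, the only number available is that of compound 2 at 5000 nM.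

The next compound to be read is compound 3 `O=CNCCCCCCNc1nc(C(=O)NCc2ccc(F)cc2)c(O)c2ncccc12`. The structural change from compound 1 is 4-(formylamino)butyl in place of hydroxy on a saturated chain carbon, two bonds along the chain from a nitrogen on an aromatic ring. Cut one bond further out, the same difference reads (2-hydroxyethyl)amino to (6-(formylamino)hexyl)amino.

Going by the values given here, with no value for compound 1 and no step between measured compounds, the size of this step in this assay cannot be read from the data. The working expectation is that compound 3 will fall in the same range as compound 2 at 5000 nM, with no direction favoured and no gap beyond the usual scatter. One value is thin support, so the range is kept wide. The estimated value for compound 3 is 5000 nM, with an expected range of 1000 nM to 25000 nM.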

Compound 3, half-maximal inhibitory concentration: 19000 nM
Beside the measured number, compound 3's estimate is 3.8-fold (0.58 log units) below it; the measured number falls inside the stated range.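

No step can be read from compound 1 to compound 3 in this assay: compound 3 gives 19000 nM, while compound 1 stands at "not determined" (no result reported). The compounds shown leave open how (6-(formylamino)hexyl)amino compares with (2-hydroxyethyl)amino on the shared core. No supporting evidence bears on this result.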